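A few compounds are considered here, and "the series" means these few. Any claim that something is new, unique, unknown or untested is made for them only; others in the source may bear on it.

The study concerns three measured compounds and one still to be measured, all examined in a functional assay on PC-3 cells (Homo sapiens) for inhibition, read by MTT assay, with a stated time of 24 h; a lower number here means a stronger inhibitor, a higher number a weaker inhibitor. Compound 1 `CCCc1cc2ccccc2nc1-c1cc(-c2ccc(C)cc2)no1` carries a propyl chain on the shared core, compound 2 `CCCCc1cc2ccccc2nc1-c1cc(-c2ccc(C)cc2)no1` a butyl chain and compound 3 `CCCCCc1cc2ccccc2nc1-c1cc(-c2ccc(C)cc2)no1` a pentyl chain. In this assay compound 1 gives > 100000 nM, which is a limit of the assay rather than a number. Compound 2 gives > 100000 nM, again a limit. Compound 3 gives > 100000 nM, once more a limit. Compound 3 thus stands at the same limit as its two companions, as the limit of > 100000 nM in this assay, at which 3 of the 3 values shown sit, records. The steps among them, a step that the two limits leave unreadable from compound 1 to compound 2, a step that the two limits leave unreadable from compound 1 to compound 3 and a step that the two limits leave unreadable from compound 2 to compound 3, cannot be read in size. Compound 4 `CCCCCc1cc2ccccc2nc1-c1cc(-c2ccc(C(F)(F)F)cc2)no1` differs from compound 3 by trifluoromethyl in place of methyl on an aromatic carbon. Within the data shown here, none of the measured steps touches that part of the molecule, and all of them leave the size of any step unreadable. Compound 4 is therefore expected to return a limit as well, so a number no higher from compound 3 to compound 4 (the limit leaves the size open) is expected to show no step beyond the scatter. Compound 4 is estimated at 100000 nM, within a range from 30000 nM to 300000 nM.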

Compound 4, half-maximal inhibitory concentration: 30200 nM
Compound 4: the middle estimate sits 3.3-fold (0.52 log units) above what was measured; the range from low to high includes it.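

Trifluoromethyl in place of methyl gives an at least 3.3-fold lower number from compound 3 to compound 4 (0.51 log units; beyond the scatter) and is the first step in this assay that can be read. Among these compounds, it shows that the number can move with a change at this position on the aromatic ring, a part of the molecule that none of the earlier steps touched, while the chain steps among the first three compounds cannot be read. On these data alone, compound 1, compound 2 and compound 3 all stay at one limit, so the true size of the new step also stays open on one side: the limit of > 100000 nM in this assay, at which 3 of the 4 values shown sit.

As far as these compounds go, whether the same change would lower the number with the propyl or butyl chain of compound 1 or compound 2 remains open. So does what a chloro group, a methoxy group or a carboxylic acid would do at this position, or a longer chain or an amine on the other side of the core.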